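Dropping the chloro from the urea aryl of compound 1

The compounds below may be only part of what the source reports. "The series", "measured", "known", "first", "only" and "open" are said of these compounds alone.

Compound 1 `O=C(Nc1ccc(-n2ccc3nc(C(=O)NCc4ccccc4)ccc32)cc1)Nc1ccc(Cl)c(C(F)(F)F)c1` is the stronger of the two compounds measured in a functional assay on A375P cells (Homo sapiens) for cytotoxicity, read by MTT assay; a lower number here means a stronger inhibitor, a higher number a weaker inhibitor: compound 1 gives 1100 nM, while compound 2 `COC(=O)c1ccc2c(ccn2-c2ccc(NC(=O)Nc3ccc(Cl)c(C(F)(F)F)c3)cc2)n1` gives 3600 nM. Among the compounds with values here, the only measured step, a 3.3-fold higher number from compound 1 to compound 2 (0.51 log units; beyond the scatter), concerns the carbonyl end of the shared core and not the urea side. Compound 3 `O=C(Nc1ccc(-n2ccc3nc(C(=O)NCc4ccccc4)ccc32)cc1)Nc1cccc(C(F)(F)F)c1` differs from compound 1 by hydrogen in place of chloro on an aromatic carbon, the change reading 4-chloro-3-(trifluoromethyl)phenyl to 3-(trifluoromethyl)phenyl. Within the data shown here, no measured pair touches this aryl, so the expectation rests only on the size of the one step seen, which was modest, and on the loss of a single heavy atom in compound 3. A modest move toward a higher number, at or just beyond the scatter, is expected, a 2.3-fold higher number from compound 1 to compound 3 (0.36 log units; beyond the scatter). For compound 3 the estimated value in this assay is 2500 nM, with a range from 900 nM to 7000 nM.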

Compound 3, half-maximal inhibitory concentration: 7900 nM
The estimate for compound 3 lay 3.2-fold (0.50 log units) below the measured number; the whole stated range lies below it.
By their numbers in this assay, from the lowest: compound 1; then compound 2; then compound 3.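

In this assay, the chloro on the urea aryl carries real weight: hydrogen in its place gives a 7.2-fold higher number from compound 1 to compound 3 (0.86 log units; beyond the scatter), even though only a single chlorine atom leaves and the trifluoromethyl group stays. Within the data shown here, the one earlier step, a 3.3-fold higher number from compound 1 to compound 2 (0.51 log units; beyond the scatter), lay at the carbonyl end of the shared core, so this is the first sign that the urea side also moves the number. No measurement offered here accounts for the size of this change.

Only chloro and hydrogen are shown at this place, so it remains open whether a fluoro, a bromo or a methyl there would hold the number of compound 1. Going by these compounds, it is also open whether losing the chloro would cost the same with the methoxy of compound 2 on the carbonyl carbon.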